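Adding a Methoxy Group Next to the Phenol

The source may hold more compounds than are shown below. What is called first, only, known or untested is meant among the compounds shown, and "the series" means these compounds.

Measured so far:
compound 1, `COc1cc(OC)c(OC)cc1/C=C/C(=O)c1ccc(C)cc1`, 2.18 ug/mL
compound 2, `COc1cc(OC)c(OC)cc1/C=C/C(=O)c1ccc(O)cc1`, 2.5 ug/mL

Both compounds were read in a functional assay, read by Griess assay, with a stated time of 2.5 h; on this read-out lower numbers stand for stronger inhibition and higher numbers for weaker inhibition. Compound 1 gives 2.18 ug/mL in this assay, and compound 2 gives 2.5 ug/mL. For the measured compounds named here, the only measured step, a 1.1-fold higher number from compound 1 to compound 2 (0.06 log units; within the scatter), lies within the scatter, so the two values cannot be ordered. Compound 2 holds the highest of the two numbers, its nearest neighbour being compound 1.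

The next compound, compound 3, `COc1cc(C(=O)/C=C/c2cc(OC)c(OC)cc2OC)ccc1O`, is not yet measured. It differs from compound 2 by methoxy in place of hydrogen on an aromatic carbon, the incoming group sitting ortho to a hydroxy group and meta to a large group.

Going by the values given here, no measured step involves a methoxy group entering at this kind of place, so nothing in the two values bears directly on the change. The step from compound 1 to compound 2 is the only reference, and it was within the scatter. With no guide pointing either way, the step from compound 2 to compound 3 is expected to be no change at the digits printed from compound 2 to compound 3 (within the scatter), no larger than the scatter. Compound 3 is therefore estimated at 2.5 ug/mL in this assay, within 1.2 ug/mL to 5.2 ug/mL.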

Compound 3, half-maximal inhibitory concentration: 2.46 ug/mL
Compound 3: the middle estimate sits 1.0-fold (0.01 log units) above what was measured, within the range that was stated.
By their numbers in this assay, from the lowest: compounds 1, 3 and 2 (each within the scatter of the next).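

In this assay, methoxy entering in place of hydrogen, ortho to a hydroxy group and meta to a large group, gives a 1.0-fold lower number from compound 2 to compound 3 (0.01 log units; within the scatter), so at this position the read-out does not separate the added group from the scatter. For the compounds shown here, the earlier compounds offered only a 1.1-fold higher number from compound 1 to compound 2 (0.06 log units; within the scatter), an exchange of methyl for hydroxy at a single place, and could say nothing about a second substituent entering on the six-membered aromatic ring of carbon only; compound 3 supplies the first reading of such an addition, and with the hydroxy group kept in place it shows no measurable shift. Nothing measured here accounts for this outcome, and the result stands as an observation about these compounds alone.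

The compounds shown leave open whether a longer chain such as ethoxy or butoxy, a halogen such as chlorine, or an amine on the same carbon would also leave the number within the scatter. They also leave open whether methoxy at this place would behave in the same way if methyl stood in place of the hydroxy group.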